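A few compounds are considered here, and "the series" means these few. Any claim that something is new, unique, unknown or untested is made for them only; others in the source may bear on it.

Measured compounds:
compound 1, `Cc1ccc(-c2nn(-c3ccccc3)cc2C(=O)NOCc2ccccc2)cc1`, 1140 nM
compound 2, `Cc1ccc(-c2nn(-c3ccccc3)cc2C(=O)NOCc2ccccc2Cl)cc1`, 380 nM
compound 3, `Cc1ccc(-c2nn(-c3ccccc3)cc2C(=O)NOCc2ccc(Cl)cc2Cl)cc1`, 1080 nM

In a functional assay on A549 cells (Homo sapiens) for antiproliferative activity, read by MTT assay, with a stated time of 48 h, in the presence of a further agent that is not named here (a lower number here means a stronger inhibitor of growth, a higher number a weaker inhibitor of growth), compound 1 stands at the highest of the three numbers; compound 3 sits within the scatter of it (a 1.1-fold lower number from compound 1 to compound 3 (0.02 log units; within the scatter)), while compound 2 is set apart (a 3.0-fold lower number from compound 1 to compound 2 (0.48 log units; beyond the scatter)). Among the measured compounds shown here, the only step beyond the scatter, and its reverse (a 2.8-fold higher number from compound 2 to compound 3 (0.45 log units; beyond the scatter)), both concern a chloro on the aromatic ring bound through a saturated carbon to oxygen.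

Compound 4, `O=C(NOCc1ccccc1)c1cn(-c2ccccc2)nc1-c1ccc(F)cc1`, is not yet measured. Its change from compound 1 is fluoro in place of methyl on an aromatic carbon. For the measured compounds named here, this touches the other aryl ring of the core, a place where none of the measured steps applies, so no measured step bears on it directly. With nothing in this assay to point either way, a step of no more than the usual scatter is expected in either direction.

Compound 4 is therefore estimated at 1100 nM, with a range of 400 nM to 3000 nM, meaning an expected step of a 1.0-fold lower number from compound 1 to compound 4 (0.02 log units; within the scatter).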

Compound 4, concentration for 50% growth inhibition: 10400 nM
Estimate against measurement, compound 4: 9.5-fold (0.98 log units) below; the whole stated range lies below it.
By their numbers in this assay, from the lowest: compound 2; then compounds 3 and 1 (each within the scatter of the next); then compound 4.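

In this assay, among the compounds shown here, replacing 4-methylphenyl with 4-fluorophenyl gives a 9.1-fold higher number from compound 1 to compound 4 (0.96 log units; beyond the scatter), the first evidence that the aromatic ring on the shared core is sensitive to the group para to a large group. The earlier steps shown here all concerned the other end of the molecule, so they gave no information about this position. This step also runs in the opposite direction to a 3.0-fold lower number from compound 1 to compound 2 (0.48 log units; beyond the scatter), showing that a single-atom change at this position can weaken growth inhibition, but no available evidence accounts for the effect of this change.

As far as these compounds go, it remains open whether the higher number follows from losing the methyl or from gaining the fluoro; a plain hydrogen, a chloro or a methoxy at this position would help separate the two. Also open, from the compounds shown here alone, is whether the chloro step from compound 1 to compound 2 would carry over to the 4-fluorophenyl series.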